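Extending the Alkyl Chain by One Carbon: Expected Cytotoxicity

The source may hold more compounds than are shown below. What is called first, only, known or untested is meant among the compounds shown, and "the series" means these compounds.

Of the compounds shown here, three built on one shared core have been tested in a functional assay on HEL cells (Homo sapiens), read by microscopy; on this read-out lower numbers stand for higher toxicity in this test and higher numbers for lower toxicity in this test. Compound 1 `CCCCCCCCCc1cc2cn(COCCO)c(O)nc-2n1` carries a nonyl chain, and in this assay compound 1 gives > 80000 nM, which is a limit of the test rather than a number. Compound 2 `CCCCc1cc2cn(COCCO)c(O)nc-2n1` carries a butyl chain; in this assay compound 2 gives > 400000 nM, again only a limit. Compound 3 `CCCCCc1cc2cn(COCCO)c(O)nc-2n1` carries a pentyl chain; in this assay compound 3 gives > 400000 nM, also a limit, so compound 3 stands at a limit and nowhere more precise. Two of the three results sit at the limit of > 400000 nM in this assay, at which 2 of the 3 values shown sit, and one at the limit of > 80000 nM in this assay, at which 1 of the 3 values shown sits. Consequently the steps a step that the two limits leave unreadable from compound 1 to compound 2, a step that the two limits leave unreadable from compound 1 to compound 3 and a step that the two limits leave unreadable from compound 2 to compound 3 cannot be read at all.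

Compound 4 `CCCCCCc1cc2cn(COCCO)c(O)nc-2n1` differs from compound 3 by methyl in place of hydrogen on a saturated chain carbon, five bonds along the chain from an aromatic carbon. Within the data shown here, since no measured step is readable, no change beyond the scatter can be expected in either direction; the step from compound 3 to compound 4 is estimated at a number no higher from compound 3 to compound 4 (the limit leaves the size open). Compound 4 is therefore expected to give 400000 nM, within 100000 nM to 1000000 nM, most probably reported again only as a limit.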

Compound 4, minimum cytotoxic concentration: > 400000 nM
Compound 4 ended at the assay's limit (the forecaster's own chance of this, stated with the estimate: 85%); the middle value sits exactly at the limit.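

In this assay compound 4 gives > 400000 nM, which is a limit of the test and not a number. No new step can be read between compound 4 and compound 1, compound 2 or compound 3. The compounds shown leave open whether chain length changes toxicity in this test at all.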